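The source may hold more compounds than are shown below. What is called first, only, known or untested is meant among the compounds shown, and "the series" means these compounds.

Compound 1 `Cc1cc(Cl)cc(-c2ccnc3cc(CN4C(=O)C5C(C4=O)C5(C)C)sc23)c1OC1CCCNC1`: 250 nM
Compound 2 `Cc1cc(Cl)cc(-c2ccnc3cc(CN4C(=O)C5C(C4=O)C5(C)C)sc23)c1NC1CCCNC1`: 33 nM
Compound 3 `Cc1cc(Cl)cc(-c2ccnc3cc(CN4C(=O)CCC4=O)sc23)c1CN1CCNC[C@@H]1C`: 280 nM

In an assay on RKO cells for inhibition of ubiquitin carboxyl-terminal hydrolase 7 (Homo sapiens), read by a luciferase reporter, with a stated time of 18 h (on this read-out lower numbers stand for an effect already at smaller amounts and higher numbers for an effect only at larger amounts of compound), compound 3 gives the highest of the three numbers; compound 1 lies within the scatter of it, whereas compound 2 lies clearly lower. Compound 4 `Cc1cc(Cl)cc(-c2ccnc3cc(CN4C(=O)CCC4=O)sc23)c1O[C@H]1CCCNC1` differs from compound 3 by (piperidin-3-yl)oxy in place of (2-methylpiperazin-1-yl)methyl on an aromatic carbon. Going by the values given here, no measured pair tests this exchange directly. Among the compounds with values here, the one measured step, a 7.6-fold lower number from compound 1 to compound 2 (0.88 log units; beyond the scatter), concerns the amino-for-oxy change and does not bear on it. What helps is that compound 1, which carries the same (piperidin-3-yl)oxy group, gives 250 nM, close to compound 3 with its 280 nM. The step of a 1.1-fold lower number from compound 3 to compound 4 (0.05 log units; within the scatter) is therefore expected to stay within the scatter. Compound 4 is estimated at 250 nM, in a range from 100 nM to 650 nM.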

Compound 4, half-maximal effective concentration: 180 nM
Beside the measured number, compound 4's estimate is 1.4-fold (0.14 log units) above it, within the range that was stated.
By their numbers in this assay, from the lowest: compound 2; then compounds 4, 1 and 3 (each within the scatter of the next).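

With the rest of compound 3 held, this position, ortho to a methyl group, accepts either (2-methylpiperazin-1-yl)methyl or (piperidin-3-yl)oxy in this assay with no difference that stands out from the scatter (a 1.6-fold lower number from compound 3 to compound 4 (0.19 log units; within the scatter)). This single step changes the ring and its hetero atoms together, so it cannot show what each contributes. No supporting data explain this result.

The compounds shown leave open how an open-chain amine, such as a 2-aminoethoxy group, or a carboxylic acid would read at this position.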